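A few compounds are considered here, and "the series" means these few. Any claim that something is new, unique, unknown or untested is made for them only; others in the source may bear on it.

Measured so far in an ADME assay on LNCaP cells (Homo sapiens) for inhibition, read by MTT assay, with a stated time of 72 h; a higher number here means that more compound is tolerated, a lower number that less compound is tolerated:

- compound 1, `CCOCc1ccc(O)c2ncccc12`: 2000 nM
- compound 2, `COc1ccc(C(NC(C)=O)c2cc([N+](=O)[O-])c3cccnc3c2O)cc1OC`: > 10000 nM
- compound 3, `Oc1ccc(CNc2cccc(C(F)(F)F)c2)c2cccnc12`: > 10000 nM

Compound 3 does not give a number in this assay; its value is a limit of the assay. Compound 2 likewise stands at a limit, not a number. Of the three values, two sit at the same limit, as the limit of > 10000 nM in this assay, at which 2 of the 3 values shown sit, records. Only compound 1 gives a number, and that number lies below the limit at which the other two stand, so less of compound 1 is tolerated than of either of the others. Compound 3 therefore stands among the compounds that are tolerated up to the limit of this assay, with no number to place it more finely.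

Compound 4, `COc1cccc(NCc2ccc(O)c3ncccc23)c1`, is not yet measured in this assay. It differs from compound 3 in one place: methoxy in place of trifluoromethyl on an aromatic carbon. No measured step between two compounds in this set is shown, so no step of the same kind can be read off. The change is small in what leaves and what enters, and compound 3 itself sits at the limit. The step of a number no higher from compound 3 to compound 4 (the limit leaves the size open) is expected to be none beyond the scatter. Compound 4 is expected at 10000 nM, within 4000 nM to 30000 nM, most likely as a limit rather than a number.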

Compound 4, half-maximal cytotoxic concentration: 5000 nM
Estimate against measurement, compound 4: 2.0-fold (0.30 log units) above, and the stated range covers the measured number.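

In this assay, going by these compounds alone, methoxy in place of trifluoromethyl on an aromatic carbon, meta to a large group, gives the first readable step: an at least 2.0-fold lower number from compound 3 to compound 4 (0.30 log units; that floor lies within the scatter). This position now has a measured number, as compound 4 gives 5000 nM. Compound 3 gives only a limit. The size of the step stays open because the value of compound 3 is a limit, and the floor alone does not separate this change from the scatter: the limit of > 10000 nM in this assay, at which 2 of the 4 values shown sit.

The compounds shown do not tell how far the true value of compound 3 lies from that of compound 4, so whether this change has any real effect on the tolerated concentration remains unsettled. With only trifluoromethyl and methoxy at this carbon, they also leave open what a carboxylic acid, a nitrile or a dimethylamino group in the same place would do in this assay, and whether methoxy would give a similar value on another carbon of the same ring.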